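Shortening the side chain of compound 1

The source may report more compounds than this note shows. Statements on the series, on what has been measured and on what is new or still open speak of the compounds shown alone.

Compound 1 `COC(=O)[C@@H](NC(=O)CSc1nc(-c2ccccc2)cc(-c2ccc(C)cc2)c1C#N)C(C)C`: > 250000 nM (a limit)
Compound 2 `Cc1ccc(-c2cc(-c3ccccc3)nc(SCC(=O)N[C@H](C(=O)O)C(C)C)c2C#N)cc1`: 250000 nM
Compound 3 `Cc1ccc(-c2cc(-c3ccccc3)nc(SCC(=O)O)c2C#N)cc1`: not yet measured

In an ADME assay on HEK-293T cells (Homo sapiens) for cytotoxicity, read by MTT assay, with a stated time of 24 h (on this read-out lower numbers stand for higher toxicity in this test and higher numbers for lower toxicity in this test), compound 1 gives > 250000 nM, which is a limit and not a number. Compound 2 gives 250000 nM in this assay. Compound 3 differs from compound 1 by hydroxy in place of (1-(methoxycarbonyl)-2-methylpropyl)amino on a carbonyl carbon. Among the measured compounds shown here, one measured step touches the group that leaves: a number no higher from compound 1 to compound 2 (the limit leaves the size open). On these data alone, its size stays unknown, and the evidence here is the limit of > 250000 nM in this assay, at which 1 of the 2 values shown sits. For the measured compounds named here, no measured step removes the whole group, so the expectation is weak. Going by compound 2 at 250000 nM, a value near the top of the measured range is expected, with any shift towards lower numbers. The expected step is an at least 1.2-fold lower number from compound 1 to compound 3 (0.09 log units; that floor lies within the scatter). Compound 3 is estimated at 200000 nM, with an expected range from 80000 nM to 300000 nM.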

Compound 3, half-maximal cytotoxic concentration: 218000 nM
Beside the measured number, compound 3's estimate is 1.1-fold (0.04 log units) below it, and the stated range covers the measured number.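

In this assay, hydroxy in place of the (1-carboxy-2-methylpropyl)amino group on the carbonyl carbon gives a 1.1-fold lower number from compound 2 to compound 3 (0.06 log units; within the scatter), so this read-out does not separate the two compounds. The earlier pair changed only the end of this side chain, whereas here nearly all of it goes and the value stays within the scatter of compound 2. Taken from the (1-(methoxycarbonyl)-2-methylpropyl)amino group, the same replacement gives an at least 1.1-fold lower number from compound 1 to compound 3 (0.05 log units; that floor lies within the scatter), and the true size of that step stays unknown because compound 1 carries a limit and not a number: the limit of > 250000 nM in this assay, at which 1 of the 3 values shown sits.

On these data alone, whether a simple amine or a longer chain on this carbonyl carbon would read the same remains open. So does the effect of replacing the nitrile on the shared core.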